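The source may hold more compounds than are shown below. What is called first, only, known or untested is meant among the compounds shown, and "the series" means these compounds.

Compound 1 `CN1CCN(C(=O)/C=C/c2ccncc2-c2ccc3ccccc3c2)CC1`: > 10000 nM, a limit
Compound 2 `COC1CN(C(=O)/C=C/c2ccncc2-c2ccc3ccccc3c2)C1`: > 10000 nM, a limit
Compound 3 `O=C(/C=C/c1ccncc1-c1ccc2ccccc2c1)N1CCOCC1`: > 10000 nM, a limit

All three were tested in a functional assay on MCF7 cells (Homo sapiens) for inhibition, read by sulforhodamine B assay, with a stated time of 72 h; on this read-out higher numbers stand for weaker inhibition of growth and lower numbers for stronger inhibition of growth. Compound 3 stands at the limit of > 10000 nM in this assay, at which 3 of the 3 values shown sit, so it has a limit and no number. Compound 4 `NC(=O)/C=C/c1ccncc1-c1ccc2ccccc2c1` changes one group on the carbonyl carbon: amino in place of morpholin-4-yl on a carbonyl carbon. Three measured steps change the group at this same place: a step that the two limits leave unreadable from compound 1 to compound 2, a step that the two limits leave unreadable from compound 1 to compound 3 and a step that the two limits leave unreadable from compound 2 to compound 3. None of them has a readable size. On the strength of these steps, no change beyond the usual scatter is expected in either direction, although limits make this a weak guide. The expected step is a step that the limit leaves unreadable from compound 3 to compound 4. Compound 4 is estimated at 12000 nM, with an expected range of 3000 nM to 30000 nM.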

Compound 4, concentration for 50% growth inhibition: > 10000 nM
Compound 4 was reported as a limit (the forecaster's own chance of this, stated with the estimate: 70%); the middle value lies beyond the limit too.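

No new step can be read: compound 4, like compound 1, compound 2 and compound 3, is reported only as a limit, so none of its steps has a size. The compounds shown leave open whether changing the group on the carbonyl carbon alters growth inhibition at all, because every result sits at the same limit: the limit of > 10000 nM in this assay, at which 4 of the 4 values shown sit.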